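A Selenium Chain Gives Way to an Amine

A few compounds are considered here, and "the series" means these few. Any claim that something is new, unique, unknown or untested is made for them only; others in the source may bear on it.

Compound 1 `CCCCC[Se]c1nc([Se]CCCCC)c2ccccc2n1` was tested in a functional assay on HTB-54 cells (Homo sapiens) for cytotoxicity, read by MTT assay, with a stated time of 72 h; a lower number here means a stronger inhibitor of growth, a higher number a weaker inhibitor of growth. In this assay compound 1 reaches only a limit, > 100000 nM, and no number. Compound 2 `[SeH]c1nc(NCc2ccccc2)c2cccnc2n1` likewise gives only a limit in this assay, > 100000 nM. Compound 3 `C[Se]c1nc([Se]C)c2ccccc2n1` is the one of the three with a number in this assay, 84200 nM. Compound 1 thus stands at the limit of > 100000 nM in this assay, at which 2 of the 3 values shown sit, and the two limits show no order between compound 1 and compound 2.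

Compound 4 `CCCCC[Se]c1nc(N)c2ccccc2n1` differs from compound 1 by one nitrogen atom in place of a group of 6 heavy atoms (5 carbon, 1 selenium; no ring), on an aromatic carbon. Among the compounds with values here, no pair of measured compounds differs in a single place, so no measured step guides the size of this change. With compound 1 at a limit, the change is expected to move the value by no more than the scatter, so the step expected from compound 1 to compound 4 in this assay is an at least 1.0-fold lower number from compound 1 to compound 4 (0.02 log units; that floor lies within the scatter). Compound 4 is therefore estimated at 95000 nM in this assay, with a range from 40000 nM to 220000 nM.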

Compound 4, concentration for total growth inhibition: 84000 nM
Compound 4: the middle estimate sits 1.1-fold (0.05 log units) above what was measured; measured number inside the range.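

In this assay compound 4 gives 84000 nM, so a compound with amino at this place on the aromatic carbon has a measured number, whereas compound 1, with the selenium chain there, has none. Exchanging that chain for amino can be read only as a floor, which is an at least 1.1-fold lower number from compound 1 to compound 4 (0.07 log units; that floor lies within the scatter). The value for compound 1 remains a limit, and such limits still make up part of the set: the limit of > 100000 nM in this assay, at which 2 of the 4 values shown sit.

The true size of the step stays open, and the compounds shown cannot tell whether the selenium chain's removal or the arrival of amino matters more. Also open, as far as these compounds go, is whether another group at this place, such as methylamino or a hydroxyl, or a shorter chain on the remaining selenium, would move the value beyond the scatter.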